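The source may hold more compounds than are shown below. What is called first, only, known or untested is meant among the compounds shown, and "the series" means these compounds.

Series of cinnamic acids on a shared core carrying a triazole whose aromatic nitrogen bears a varied aryl group. Compound 1 `COc1ccc(/C=C\C(=O)O)c(OCc2cn(-c3ccccc3F)nn2)c1CC=C(C)C` has "not determined" (no result reported) in a functional assay on HCT-116 cells (Homo sapiens) for cytotoxicity, read by MTT assay, with a stated time of 24 h; on this read-out higher numbers stand for weaker inhibition and lower numbers for stronger inhibition. Compound 2 `COc1ccc(/C=C\C(=O)O)c(OCc2cn(-c3ccccc3)nn2)c1CC=C(C)C` gives 26000 nM in this assay, the highest of the two numbers in hand. Compound 3 `COc1ccc(/C=C\C(=O)O)c(OCc2cn(-c3nc4ccccc4s3)nn2)c1CC=C(C)C` gives 16400 nM in this assay; the move a 1.6-fold lower number from compound 2 to compound 3 (0.20 log units; within the scatter) stays inside the scatter, so the two cannot be ordered.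

Compound 4 `COc1ccc(/C=C\C(=O)O)c(OCc2cn(-c3cccc([N+](=O)[O-])c3)nn2)c1CC=C(C)C` is not yet measured. Relative to compound 2 it differs by nitro in place of hydrogen on an aromatic carbon. Among the compounds with values here, no measured pair changes a substituent on that phenyl ring; the only step touching the same site is the swap of the whole aryl group, a 1.6-fold lower number from compound 2 to compound 3 (0.20 log units; within the scatter), which was within the scatter. On that evidence no step beyond the scatter is expected from compound 2 to compound 4, in either direction. Compound 4 is therefore expected to give about 22000 nM in this assay, within 9000 nM to 55000 nM, which corresponds to an expected 1.2-fold lower number from compound 2 to compound 4 (0.07 log units; within the scatter).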

Compound 4, half-maximal inhibitory concentration: 27300 nM
For compound 4 the middle estimate is 1.2-fold (0.09 log units) below the measured one; the range from low to high includes it.
By their numbers in this assay, from the lowest: compounds 3, 2 and 4 (each within the scatter of the next).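

In this assay, the first substituent on the phenyl ring shows no resolvable effect: nitro on an aromatic carbon, meta to a large group, gives a 1.1-fold higher number from compound 2 to compound 4 (0.02 log units; within the scatter) and so does not separate the 3-nitrophenyl group from phenyl. The comparison with the other aryl group gives the same picture, with a 1.7-fold higher number from compound 3 to compound 4 (0.22 log units; within the scatter) on exchanging 1,3-benzothiazol-2-yl for 3-nitrophenyl, so these aryl groups on the aromatic nitrogen cannot be ordered. No measurement shown here offers an explanation for this flat result.

In this assay, going by these compounds, compound 1 stands at "not determined" (no result reported) and has no number, so its steps cannot be read and the effect of the fluorine on that ring stays unknown. On these data alone, whether an amine or a hydroxyl group on the phenyl ring would produce a step beyond the scatter remains open.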